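This account rests on a few compounds, and the source may have more. Where it says the series, first, only, none or still open, it means among the compounds named here.

Compound 3 `O=C(O)Cc1sc(C(c2ccc(F)cc2)c2ccc(F)cc2)nc1-c1ccnc(Cl)c1` gives 80% in an in vitro functional assay on HEK285-7 cells for antagonist activity at prostaglandin D2 receptor 2 (Homo sapiens), read by BRET and beta-arrestin recruitment; on this read-out lower numbers stand for smaller maximal responses and higher numbers for larger maximal responses. Compound 1 `N#Cc1cc(-c2nc(C(c3ccc(F)cc3)c3ccc(F)cc3)sc2CC(=O)O)ccc1F` gives 80% in this assay, and compound 2 `O=C(O)Cc1sc(C(c2ccc(F)cc2)c2ccc(F)cc2)nc1-c1ccccc1` gives 80%, so compound 3 stands level with both at the digits shown. The step of no change at the digits printed from compound 1 to compound 3 (within the scatter), the step of no change at the digits printed from compound 2 to compound 3 (within the scatter) and the step of no change at the digits printed from compound 1 to compound 2 (within the scatter) all leave the maximal response where it was. Compound 4 `Cc1cc(-c2nc(C(c3ccc(F)cc3)c3ccc(F)cc3)sc2CC(=O)O)ccn1` differs from compound 3 by methyl in place of chloro on an aromatic carbon. All three measured steps alter the same part of the shared core and were flat, so no step beyond the scatter is expected in this assay. The expected step is no change at the digits printed from compound 3 to compound 4 (within the scatter). Compound 4 is therefore estimated at 80%, with a range from 68% to 92%.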

Compound 4, largest response reached (reported as efficacy), in percent of the reference or control that the assay uses: 80%
Estimate against measurement, compound 4: no gap at the digits printed; measured number inside the range.
By their numbers in this assay, from the lowest: compounds 1, 2, 3 and 4 (each within the scatter of the next).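

In this assay, putting methyl in place of chloro next to the ring nitrogen gives no change at the digits printed from compound 3 to compound 4 (within the scatter), so this carbon carries either group with the maximal response held. The 2-methylpyridin-4-yl group also matches the earlier aryl groups, with no change at the digits printed from compound 2 to compound 4 (within the scatter) and no change at the digits printed from compound 1 to compound 4 (within the scatter). Nothing available explains this flat result.

From the compounds shown here alone, whether an amine or a methoxy group on this carbon would also leave the response in place stays open. So does whether an amide in place of the carboxylic acid would do so.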